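Removing the methoxy group: compound 4 in the growth assay

The source may report more compounds than this note shows. Statements on the series, on what has been measured and on what is new or still open speak of the compounds shown alone.

Measured compounds:
- Compound 1, `COc1cccc(CN2CC=C(CCC(=O)NO)C2=O)c1`: 3890 nM
- Compound 2, `O=C(CCC1=CCN(Cc2cccc(C(F)(F)F)c2)C1=O)NO`: 880 nM
- Compound 3, `COc1ccc(CCCN2CC=C(CCC(=O)NO)C2=O)cc1`: 7000 nM

In a functional assay on PC-3 cells (Homo sapiens) for antiproliferative activity (a lower number here means a stronger inhibitor of growth, a higher number a weaker inhibitor of growth), compound 1 gives 3890 nM, the second highest of the three numbers. Its nearest neighbour is compound 3 at 7000 nM, a gap that lies within the scatter, so the two cannot be ordered. Compound 2, at 880 nM, sits furthest away, and the step of a 4.4-fold lower number from compound 1 to compound 2 (0.65 log units; beyond the scatter) shows a modest gain that goes beyond the scatter.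

Compound 4, `O=C(CCC1=CCN(Cc2ccccc2)C1=O)NO`, differs from compound 1 in one place: hydrogen in place of methoxy on an aromatic carbon. Within the data shown here, no measured step covers this exact change. Among the measured compounds shown here, the only step at the same site, a 4.4-fold lower number from compound 1 to compound 2 (0.65 log units; beyond the scatter), exchanges one substituent for another rather than removing one, so it offers only an indirect guide. With nothing firmer to lean on, the step from compound 1 to compound 4 is expected to be small, a 1.1-fold lower number from compound 1 to compound 4 (0.05 log units; within the scatter), in either direction or none beyond the scatter. For compound 4 the expected number in this assay is 3500 nM, with a range from 1200 nM to 10000 nM.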

Compound 4, concentration for 50% growth inhibition: 4430 nM
Compound 4: middle estimate off by 1.3-fold (0.10 log units), on the low side; the range from low to high includes it.
By their numbers in this assay, from the lowest: compound 2; then compounds 1, 4 and 3 (each within the scatter of the next).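

Swapping the methoxy for hydrogen on this aromatic carbon leaves this assay without a readable change, with a 1.1-fold higher number from compound 1 to compound 4 (0.06 log units; within the scatter), so the methoxy group shows no contribution of its own at this place. The position itself is not indifferent, however: a 5.0-fold higher number from compound 2 to compound 4 (0.70 log units; beyond the scatter), which shows that the lower number of compound 2 holds against the unsubstituted ring as well as against the methoxy compound. Trifluoromethyl is thus the only one of these three groups that separates from the others at this place, and nothing available here accounts for that difference.

Going by these compounds, whether a chlorine atom or a nitrile on the same aromatic carbon would follow trifluoromethyl or stay with hydrogen and methoxy remains open. So does the outcome for an amine or a carboxylic acid there.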